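The source may report more compounds than this note shows. Statements on the series, on what has been measured and on what is new or still open speak of the compounds shown alone.

Measured so far:
compound 1 `CCOC(=O)c1c(-c2c(Cl)c3ccccc3oc2=O)nn(-c2cccc(C)c2)c1C(=O)OCC` — in a functional assay on DU-145 cells (Homo sapiens) for cytotoxicity, read by MTT assay, with a stated time of 48 h (a higher number here means a weaker inhibitor, a lower number a stronger inhibitor), compound 1 gives 32000 nM;
compound 2 `CCOC(=O)c1c(-c2c(Cl)c3ccccc3oc2=O)nn(-c2cccc(Cl)c2)c1C(=O)OCC` — compound 2 gives 24000 nM;
compound 3 `CCOC(=O)c1c(-c2cc3ccc(OC)cc3oc2=O)nn(-c2cccc(C)c2)c1C(=O)OCC` — compound 3 gives 35000 nM.

Compounds 1 and 2 share one core and compound 3 carries another; the difference between the two cores is not broken down here. Compound 2 arises from compound 1 by chloro in place of methyl on an aromatic carbon, and that step came out as a 1.3-fold lower number from compound 1 to compound 2 (0.12 log units; within the scatter). Compound 4 `CCOC(=O)c1c(-c2cc3ccc(OC)cc3oc2=O)nn(-c2cccc(Cl)c2)c1C(=O)OCC`, not yet measured, stands to compound 3 exactly as compound 2 stands to compound 1: chloro in place of methyl on an aromatic carbon, the same change at the same place. On the strength of that earlier step, the step from compound 3 to compound 4 is expected to be a 1.3-fold lower number from compound 3 to compound 4 (0.11 log units; within the scatter) in this assay. Compound 4 is therefore estimated at 27000 nM, expected to fall between 12000 nM and 60000 nM.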

Compound 4, half-maximal inhibitory concentration: 38000 nM
The estimate for compound 4 lay 1.4-fold (0.15 log units) below the measured number; measured number inside the range.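

The change from 3-methylphenyl to 3-chlorophenyl on the core of compound 3 came out as a 1.1-fold higher number from compound 3 to compound 4 (0.04 log units; within the scatter) in this assay. Set beside the earlier step on the core of compound 1, it does not differ by more than repeated measurement allows: the same change on two cores in this assay, a 1.3-fold lower number (0.12 log units; within the scatter) from compound 1 to compound 2 and a 1.1-fold higher number (0.04 log units; within the scatter) from compound 3 to compound 4, 1.4-fold (0.16 log units) apart, within the scatter of two such steps. Neither step lies beyond the scatter, so the pair shows no measurable effect of this change on either core and cannot test whether a real effect would carry from one core to the other.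

The compounds shown hold only methyl and chloro at this place, on two cores. As far as these compounds go, whether an amine or a carboxylic acid there would move the number beyond the scatter, and do so alike on both cores, stays open.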